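Extending the Ester Chain of Compound 3

The compounds below may be only part of what the source reports. "The series", "measured", "known", "first", "only" and "open" are said of these compounds alone.

Compound 1 `CCNS(=O)(=O)c1cccc(-c2ccc(OCC)cc2)c1` gives 200000 nM in an assay on COS-7 cells for inhibition of patatin-like phospholipase domain-containing protein 2 (Mus musculus); a lower number here means a stronger inhibitor, a higher number a weaker inhibitor.
Compound 2 `CCOc1ccc(-c2cccc(S(=O)(=O)NC)c2)cc1` gives 200000 nM in this assay.
Compound 3 `CCCCOC(=O)c1cccc(-c2ccc(OCC)cc2)c1` gives 100000 nM in this assay.

Compound 3 has the lowest of the three numbers, yet the gaps to compound 1 and compound 2 both lie within the scatter, so no order among them can be read. Compound 4 `CCOc1ccc(-c2cccc(C(=O)OCCOCCOC)c2)cc1` differs from compound 3 by 2-methoxyethoxy in place of ethyl on a saturated chain carbon, two bonds along the chain from an oxygen next to a carbonyl group. For the measured compounds named here, no measured step touches this chain: no change at the digits printed from compound 1 to compound 2 (within the scatter) concerns the sulfonamide nitrogen, while a 2.0-fold lower number from compound 1 to compound 3 (0.30 log units; within the scatter) and a 2.0-fold lower number from compound 2 to compound 3 (0.30 log units; within the scatter) exchange the whole aromatic substituent, and all three stay within the scatter. With nothing to point either way, compound 4 is expected to show no step beyond the scatter, no change at the digits printed from compound 3 to compound 4 (within the scatter). Compound 4 is therefore estimated at 100000 nM in this assay, within 30000 nM to 300000 nM.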

Compound 4, half-maximal inhibitory concentration: > 200000 nM
Compound 4: no number, only a limit; the forecaster's own chance of this, stated with the estimate: 40%; at least 2.0-fold (0.30 log units) between middle value and limit.
By their numbers in this assay, from the lowest: compounds 3, 1 and 2 (each within the scatter of the next).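

For the compounds shown here, the ester chain, which no earlier step touched, now has a reading: an at least 2.0-fold higher number from compound 3 to compound 4 (0.30 log units; that floor lies within the scatter). Replacing the butyl ester chain with 2-(2-methoxyethoxy)ethyl thus gives no sign of a lower number in this assay, although the floor of this step does not go beyond the scatter. For compound 4 this reading is a limit of the assay and not a number: the limit of > 200000 nM in this assay, at which 1 of the 4 values shown sits.

The compounds shown leave open whether a methyl ester, a plain hexyl ester or a free carboxylic acid would move the number beyond the scatter. They also leave open what an amine at the end of the ester chain would do.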